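The compounds below may be only part of what the source reports. "The series", "measured", "known", "first", "only" and "open" are said of these compounds alone.

Measured so far in a toxicity assay on NIH3T3 cells (Mus musculus) for cytotoxicity, read by resazurin assay; a higher number here means that more compound is needed for the effect, a lower number that less compound is needed:
Compound 1, `COC(=O)c1ccc(NCc2cncn2Cc2cccc(C#N)c2)cc1-c1ccccc1`: compound 1 gives > 10000 nM, which is a limit of the assay rather than a number.
Compound 2, `COc1ccc(NCc2cncn2Cc2ccc(-c3ccccc3)cc2N)cc1-c1ccccc1`: compound 2 gives > 1000 nM, also a limit.
Compound 3, `c1ccc(-c2ccc(Cn3cncc3CNc3ccc(-c4nc5ccccc5o4)c(-c4ccccc4)c3)cc2)cc1`: compound 3 gives > 10000 nM, again a limit.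

Compound 3 therefore stands at a limit, not at a measured value. Two of the three values sit at the limit of > 10000 nM in this assay, at which 2 of the 3 values shown sit, and one sits at the limit of > 1000 nM in this assay, at which 1 of the 3 values shown sits. Compound 4, `Clc1ccc(NCc2cncn2Cc2ccc(-c3ccccc3)cc2)cc1-c1ccccc1`, differs from compound 3 by chloro in place of 1,3-benzoxazol-2-yl on an aromatic carbon. Among the measured compounds shown here, no measured pair of compounds shows this kind of change, so no size of step is known for it. In this assay, the step that the limit leaves unreadable from compound 3 to compound 4 is expected to be none beyond the usual scatter, with a limit again likely. Compound 4 is thus estimated at 20000 nM, in a range from 5000 nM to 100000 nM.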

Compound 4, half-maximal effective concentration: > 1000 nM
Compound 4 ended at the assay's limit; the forecaster's own chance of this, stated with the estimate: 80%; the middle value does not contradict the limit.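

Compound 3 and compound 4 both stand at limits rather than numbers, so the size of the step between them cannot be read. The compounds shown leave open whether swapping 1,3-benzoxazol-2-yl for chloro changes the concentration needed for cytotoxicity.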